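The source may hold more compounds than are shown below. What is called first, only, known or untested is meant among the compounds shown, and "the series" means these compounds.

Compound 1 `CCCn1c(=O)[nH]c2nc(-c3ccc(S(=O)(=O)N4CCN(c5ccccc5Br)CC4)cc3)[nH]c2c1=O` was examined in an assay on CHO cells for displacement of a labelled ligand from adenosine receptor A1 (Homo sapiens), read by scintillation counting, with a stated time of 90 min, in the presence of a further agent that is not named here; on this read-out higher numbers stand for weaker inhibition and lower numbers for stronger inhibition. In this assay compound 1 gives > 1000 nM, which is a limit of the assay rather than a number. Compound 1 thus stands at the limit of > 1000 nM in this assay, at which 2 of the 2 values shown sit. Compound 2 `CCCn1c(=O)c2[nH]c(-c3ccc(S(=O)(=O)N4CCN(c5ccc(Cl)cc5)CC4)cc3)nc2n(CC)c1=O` is a related analogue. In this assay compound 2 gives > 1000 nM, again only a limit. Compound 3 `CCCn1c(=O)[nH]c2nc(-c3ccc(S(=O)(=O)N4CCN(c5ccccc5)CC4)cc3)[nH]c2c1=O` differs from compound 1 by hydrogen in place of bromo on an aromatic carbon. For the measured compounds named here, no measured step covers this change, so the shift is expected to stay small, a step that the limit leaves unreadable from compound 1 to compound 3, not beyond the scatter. Compound 3 is therefore estimated at 2000 nM in this assay, with a range from 600 nM to 8000 nM.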

Compound 3, inhibition constant: 364 nM
Beside the measured number, compound 3's estimate is 5.5-fold (0.74 log units) above it, outside the stated range (below it).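

Going from the 2-bromophenyl to the phenyl group in this assay gives an at least 2.7-fold lower number from compound 1 to compound 3 (0.43 log units; beyond the scatter), so on this aromatic carbon, ortho to a large group, hydrogen gives stronger inhibition than bromo. This is the first change shown that brings a compound to a number rather than a limit. The step's full size cannot be read, since it starts from a limit: the limit of > 1000 nM in this assay, at which 2 of the 3 values shown sit.

The compounds shown leave open whether fluoro, methyl or methoxy at this place would read closer to hydrogen or to bromo. They also leave open how large the step from bromo to hydrogen really is.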